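A Smaller Aryl Sulfone in a Permeability Series

The source may hold more compounds than are shown below. What is called first, only, known or untested is meant among the compounds shown, and "the series" means these compounds.

Compound 1 `CCCCc1nc(=O)c(S(=O)(=O)c2ccc(-c3cccnc3)cc2)c(O)n1-c1c(OC)cccc1OC`: 6 nm/s
Compound 2 `CCCCc1[nH]c(=O)c(S(=O)(=O)c2ccc(-n3ccccc3=O)cc2)c(O)c1-c1c(OC)cccc1OC`: 5 nm/s
Compound 3 `COc1cccc(OC)c1-n1c(CCC(C)C)nc(=O)c(S(=O)(=O)c2ccc(-c3ccc(F)nc3)cc2)c1O`: 35 nm/s

In an ADME assay for permeability, using PAMPA, at pH 7.4 (on this read-out lower numbers stand for lower permeability and higher numbers for higher permeability), compound 1 gives 6 nm/s, the second highest of the three numbers. Compound 2 gives 5 nm/s, a number within the scatter of compound 1. Compound 3 gives 35 nm/s, which lies beyond the scatter above compound 1. Compound 4 `CCCCc1nc(=O)c(S(=O)(=O)c2ccccc2)c(O)n1-c1c(OC)cccc1OC` has not yet been measured in this assay. It differs from compound 1 by hydrogen in place of pyridin-3-yl on an aromatic carbon, in words hydrogen in place of pyridin-3-yl on an aromatic carbon. Within the data shown here, no measured pair shows this change, so the step rests on judgement alone. A modest rise, hardly larger than the scatter, is expected as a 1.7-fold higher number from compound 1 to compound 4 (0.22 log units; within the scatter). Compound 4 is therefore estimated at 10 nm/s, with a range from 3 nm/s to 30 nm/s.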

Compound 4, apparent permeability: 1.5 nm/s
For compound 4 the middle estimate is 6.7-fold (0.82 log units) above the measured one; the whole stated range lies above it.
By their numbers in this assay, from the lowest: compound 4; then compounds 2 and 1 (each within the scatter of the next); then compound 3.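

In this assay, among these compounds, hydrogen in place of pyridin-3-yl on this aromatic carbon gives a 4.0-fold lower number from compound 1 to compound 4 (0.60 log units; beyond the scatter), the first step that isolates a single change. It shows that the read-out responds to the group at this position and that the pyridin-3-yl compound stands higher than the bare phenyl compound. Nothing at hand bears on why this step arises. The compounds shown leave open whether a smaller group here, such as a methyl group or an amine, would stand nearer compound 1 or compound 4. They also leave open whether the step keeps its size with the different chain of compound 3.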